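A few compounds are considered here, and "the series" means these few. Any claim that something is new, unique, unknown or untested is made for them only; others in the source may bear on it.

Compound 3 `C/C=C1/[C@H](O[C@@H]2O[C@H](CO)[C@@H](O)[C@H](O)[C@H]2O)OC=C(C(=O)OC)[C@H]1CC(=O)OCCc1ccc(OC)c(OC)c1` carries the shared core with a 3,4-dimethoxyphenyl group on a saturated chain carbon, two bonds along the chain from an oxygen next to a carbonyl group. In a functional assay on SK-BR-3 cells (Homo sapiens) for antiproliferative activity, read by MTT assay, with a stated time of 72 h (on this read-out higher numbers stand for weaker inhibition and lower numbers for stronger inhibition), compound 3 gives > 15000 nM, which is a limit of the assay rather than a number. Compound 1 `C/C=C1/[C@H](O[C@@H]2O[C@H](COC(C)=O)[C@@H](OC(C)=O)[C@H](OC(C)=O)[C@H]2OC(C)=O)OC=C(C(=O)O)[C@H]1CC(=O)OC` gives > 20000 nM in this assay, again a limit. Compound 2 `C/C=C1/[C@H](O[C@@H]2O[C@H](COC(C)=O)[C@@H](OC(C)=O)[C@H](OC(C)=O)[C@H]2OC(C)=O)OC=C(C(=O)O)[C@H]1CC(=O)O` gives > 20000 nM, also a limit. The step that the two limits leave unreadable from compound 1 to compound 2 therefore cannot be sized. Compound 3 stands at the limit of > 15000 nM in this assay, at which 1 of the 3 values shown sits. The two remaining values sit at the limit of > 20000 nM in this assay, at which 2 of the 3 values shown sit. Compound 4 `C/C=C1/[C@H](O[C@@H]2O[C@H](CO)[C@@H](O)[C@H](O)[C@H]2O)OC=C(C(=O)OC)[C@H]1CC(=O)OCCc1ccc2c(c1)OCCO2` differs from compound 3 by 2,3-dihydro-1,4-benzodioxin-6-yl in place of 3,4-dimethoxyphenyl on a saturated chain carbon, two bonds along the chain from an oxygen next to a carbonyl group. Among the measured compounds shown here, no measured step concerns this kind of change, and the single measured step is unreadable, so no shift beyond the scatter is expected from this replacement. Compound 4 is expected to give 20000 nM in this assay, within a range of 7000 nM to 60000 nM, and most likely to be reported only as a limit. The expected step is a step that the limit leaves unreadable from compound 3 to compound 4.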

Compound 4, half-maximal inhibitory concentration: > 20000 nM
Compound 4: a limit, no number; the forecaster's own chance of this, stated with the estimate: 80%; the middle value lies on the limit itself.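

In this assay compound 3 and compound 4 both give limits and not numbers, so the step between them cannot be read. The compounds shown leave open how strongly any of them inhibits these cells, and whether 3,4-dimethoxyphenyl and 2,3-dihydro-1,4-benzodioxin-6-yl differ at all.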